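The compounds below may be only part of what the source reports. "The series", "measured", "known", "first", "only" and "open" are said of these compounds alone.

In a functional assay on HeLa cells (Homo sapiens) for cytotoxicity, read by MTT assay, with a stated time of 48 h (a lower number here means a stronger inhibitor, a higher number a weaker inhibitor), compound 1 `O=c1cc(-c2ccc(Cl)cc2)nc2ccccn12` gives 2000 nM. Compound 2 `O=c1c(-c2ccccc2)cnc2c(OCc3ccccc3)cccn12` gives 1500 nM, and compound 3 `Cc1ccc(-c2cnc3ccccn3c2=O)cc1` gives 3000 nM. Compound 1 therefore lies within the scatter of both compound 2 and compound 3, and these values set no ranking. Compound 4 `O=Cc1ccc(-c2cc(=O)n3ccccc3n2)cc1` has formyl in place of chloro on an aromatic carbon, para to a large group: formyl in place of chloro on an aromatic carbon. Among the measured compounds shown here, no measured pair shows a comparable single change, so the data offer no direct guide. No step beyond the scatter is expected in this assay, an expectation resting only on the closeness of the three measured values. The expected step is no change at the digits printed from compound 1 to compound 4 (within the scatter). For compound 4 the estimate is 2000 nM, with an expected range of 700 nM to 6000 nM.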

Compound 4, half-maximal inhibitory concentration: 3000 nM
Compound 4: middle estimate off by 1.5-fold (0.18 log units), on the low side; low and high end bracket the measured number.
By their numbers in this assay, from the lowest: compounds 2, 1, 3 and 4 (each within the scatter of the next).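

In this assay, among the compounds shown here, formyl in place of chloro on an aromatic carbon, para to a large group, gives a 1.5-fold higher number from compound 1 to compound 4 (0.18 log units; within the scatter) and is the first single change that can be read. At this position, exchanging chloro for formyl, which adds a hydrogen-bond acceptor and a double bond outside the aromatic rings, gives no step beyond the scatter. No measurement shown explains this result. As far as these compounds go, whether an amine or a carboxylic acid at this position would give a step beyond the scatter remains open.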